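The compounds below may be only part of what the source reports. "The series", "measured", "known", "first", "only" and "open" are said of these compounds alone.

Compound 1 `CC(C)c1[nH]cnc1/C=c1\[nH]c(=O)/c(=C/c2cccc(C(=O)c3ccc(F)cc3)c2)[nH]c1=O` and compound 2 `O=c1[nH]/c(=C\c2c[nH]cn2)c(=O)[nH]/c1=C\c1cccc(Oc2ccc(F)cc2)c1` were both tested in a functional assay on NCI-H460 cells (Homo sapiens) for cytotoxicity, read by MTT assay, with a stated time of 72 h; on this read-out lower numbers stand for stronger inhibition and higher numbers for weaker inhibition. Compound 1 gives 3.2 nM, while compound 2 gives 479 nM, the higher of the two numbers, and the gap between them lies well beyond the usual scatter. Compound 3 `O=c1[nH]/c(=C\c2ccc([N+](=O)[O-])o2)c(=O)[nH]/c1=C\c1cccc(Oc2ccc(F)cc2)c1` has not been measured; it differs from compound 2 by 5-nitrofuran-2-yl in place of 1H-imidazol-4-yl on a double-bonded chain carbon bound to an aromatic carbon. For the measured compounds named here, no measured pair shows this change, so the step from compound 2 to compound 3 is expected to be small, a 1.3-fold higher number from compound 2 to compound 3 (0.10 log units; within the scatter), with no firm direction. Compound 3 is therefore estimated at 600 nM, within a range of 150 nM to 2500 nM.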

Compound 3, half-maximal inhibitory concentration: > 1000 nM
Compound 3: no number, only a limit (the forecaster's own chance of this, stated with the estimate: 5%); middle value at least 1.6-fold (0.22 log units) away from the limit.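

In this assay compound 3 gives only a limit, not a number: the limit of > 1000 nM in this assay, at which 1 of the 3 values shown sits.

Even so, 5-nitrofuran-2-yl in place of 1H-imidazol-4-yl gives an at least 2.0-fold higher number from compound 2 to compound 3 (0.31 log units; beyond the scatter), the first single-place step shown on a double-bonded chain carbon bound to an aromatic carbon, so the number here does respond to the ring carried at this place. The full size of the step cannot be read, only its lower bound.

Still open, as far as these compounds go, is whether the furan ring or the nitro group accounts for the step. A plain furan-2-yl at this place would separate the two.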